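Removing an acetyl from a phenolic oxygen in coumarin amides

The source may hold more compounds than are shown below. What is called first, only, known or untested is meant among the compounds shown, and "the series" means these compounds.

Measured compounds and their values:
- Compound 1, `COc1ccc(Oc2ccc3cc(NC(=O)c4ccc(O)c(CC=C(C)C)c4)c(=O)oc3c2C)cc1`, 42700 nM
- Compound 2, `COc1cccc(Oc2ccc3cc(NC(=O)c4ccc(O)c(CC=C(C)C)c4)c(=O)oc3c2C)c1`, 33100 nM
- Compound 3, `CC(=O)Oc1ccc(C(=O)Nc2cc3ccc(Oc4ccc(C(C)(C)C)cc4)c(C)c3oc2=O)cc1CC=C(C)C`, 72400 nM

All three compounds were tested in a functional assay on SK-BR-3 cells (Homo sapiens) for antiproliferative activity; a higher number here means a weaker inhibitor, a lower number a stronger inhibitor. Compound 3 gives the highest of the three numbers: compared with compound 1 its number is higher but within the scatter, and compared with compound 2 it is higher by a margin beyond the scatter. Compound 4, `CC(C)=CCc1cc(C(=O)Nc2cc3ccc(Oc4ccc(C(C)(C)C)cc4)c(C)c3oc2=O)ccc1O`, has not yet been measured. It differs from compound 3 in one place: hydrogen in place of acetyl on an oxygen on an aromatic ring. Within the data shown here, the only measured step that changes one place, a 1.3-fold lower number from compound 1 to compound 2 (0.11 log units; within the scatter), moves a methoxy group on the aryloxy ring and says nothing about the acetyl. Among the measured compounds shown here, no measured step touches the oxygen where compound 3 and compound 4 differ. What the values do show is that compound 1 and compound 2, which both carry a free hydroxy at that oxygen, sit at lower numbers than compound 3, though their aryloxy groups also differ from that of compound 3, so the comparison is not clean. On that basis the expected step of a 1.8-fold lower number from compound 3 to compound 4 (0.26 log units; within the scatter) is toward a modestly lower number, with wide uncertainty. Compound 4 is therefore estimated at 40000 nM, within a range from 15000 nM to 110000 nM.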

Compound 4, half-maximal inhibitory concentration: 68300 nM
Compound 4: middle estimate off by 1.7-fold (0.23 log units), on the low side; low and high end bracket the measured number.
By their numbers in this assay, from the lowest: compounds 2, 1, 4 and 3 (each within the scatter of the next, the first and the last beyond it).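

In this assay, acetoxy to hydroxy on the aromatic ring gives a 1.1-fold lower number from compound 3 to compound 4 (0.03 log units; within the scatter) and so leaves the number unchanged within the scatter, which means that, alongside the 4-(tert-butyl)phenyl group, the acetyl on this oxygen can be kept or removed with no readable effect. Among these compounds, with the free hydroxy held in place, changing the group at the far end of the aryloxy ring gives a 2.1-fold higher number from compound 2 to compound 4 (0.31 log units; beyond the scatter) for 4-(tert-butyl)phenyl in place of 3-methoxyphenyl, a modest step beyond the scatter, but a 1.6-fold higher number from compound 1 to compound 4 (0.20 log units; within the scatter) for tert-butyl in place of methoxy, so only one of these two comparisons can be read as a real difference. No supporting measurement bears on why the acetyl makes no readable difference here.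

As far as these compounds go, whether the same holds for the acetyl when the aryloxy group is the 4-methoxyphenyl of compound 1 or the 3-methoxyphenyl of compound 2 remains open. Also open, from the compounds shown here alone, is how this oxygen would respond to a different group, such as a methyl ether, or to replacing the oxygen with an amine.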